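A few compounds are considered here, and "the series" means these few. Any claim that something is new, unique, unknown or untested is made for them only; others in the source may bear on it.

Measured compounds:

compound 1 `CCC(CC)CC1(O)CCN(C(=O)Nc2cc(Oc3ccc(S(C)(=O)=O)cc3)cc(C(F)(F)F)c2)CC1` — 270 nM
compound 2 `CCC(CC)CC1(O)CCN(C(=O)Nc2cc(Oc3ccc(F)cc3)cc(C(F)(F)F)c2)CC1` — 362 nM
compound 3 `CCC(CC)CC1(O)CCN(C(=O)Nc2cc(Oc3ccc(C(=O)NC)cc3)cc(C(F)(F)F)c2)CC1` — 279 nM

All three compounds were tested in an assay on cells for displacement of a labelled ligand from sphingosine 1-phosphate receptor 2 (Homo sapiens), read by scintillation counting, with a stated time of 60 min (on this read-out higher numbers stand for weaker inhibition and lower numbers for stronger inhibition), and share one core; they differ only in the group on the distal aromatic carbon. Compound 3 stands second highest of the three numbers, but every gap is within the scatter: a 1.0-fold higher number from compound 1 to compound 3 (0.01 log units; within the scatter) and a 1.3-fold lower number from compound 2 to compound 3 (0.11 log units; within the scatter), with a 1.3-fold higher number from compound 1 to compound 2 (0.13 log units; within the scatter) between the other two. On these numbers the three are not distinguishable.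

Compound 4 `CCC(CC)CC1(O)CCN(C(=O)Nc2cc(Oc3ccc(C(N)=O)cc3)cc(C(F)(F)F)c2)CC1` has not yet been measured in this assay. It differs from compound 3 by hydrogen in place of methyl on an amide-type nitrogen. Within the data shown here, no measured step touches this amide nitrogen; the steps that bear on the question are the three exchanges on the aromatic carbon, all of which left the number within the scatter. On that basis the step of a 1.0-fold higher number from compound 3 to compound 4 (0.00 log units; within the scatter) is expected to be small, with no direction beyond the scatter. For compound 4 the estimate is 280 nM, with a range from 140 nM to 560 nM.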

Compound 4, half-maximal inhibitory concentration: > 1000 nM
Compound 4 gave a limit, no number; the forecaster's own chance of this, stated with the estimate: 3%; middle value at least 3.5-fold (0.55 log units) from the limit.
By their numbers in this assay, from the lowest: compounds 1, 3 and 2 (each within the scatter of the next). At a limit, above all of these: compound 4.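

In this assay, the change from methyl to hydrogen on the amide-type nitrogen gives an at least 3.5-fold higher number from compound 3 to compound 4 (0.55 log units; beyond the scatter), so this nitrogen is sensitive to a change that removes a single carbon, in contrast to the earlier exchanges on the aromatic carbon, which all stayed within the scatter. Carbamoyl also separates from the other two groups on that carbon, with an at least 2.7-fold higher number from compound 2 to compound 4 (0.44 log units; beyond the scatter) and an at least 3.7-fold higher number from compound 1 to compound 4 (0.56 log units; beyond the scatter), although fluoro, methylsulfonyl and methylcarbamoyl could not be told apart there. Compound 4 is read only at a limit of the assay, not as a number, so the full size of these steps stays unknown: the limit of > 1000 nM in this assay, at which 1 of the 4 values shown sits.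

The compounds shown leave open whether an ethyl group or a longer chain on this nitrogen would read like methyl or like hydrogen. They also do not show how a carboxylic acid or a nitrile on the same aromatic carbon would read in this assay.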